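The source may report more compounds than this note shows. Statements on the series, on what has been measured and on what is new or still open speak of the compounds shown alone.

Compound 2 `Cc1cc(C(=O)NCc2ccc(CNS(=O)(=O)c3ccc4c(c3)CCO4)cc2)n(C)n1` was tested in an assay on cells for inhibition of C-X-C chemokine receptor type 4 (Homo sapiens), with a stated time of 22 h, tested at 100 nM (a lower number here means less inhibition, a higher number more inhibition at the concentration tested (going by the name of the read-out)), where compound 2 is recorded as "active" (no number reported) with no single number. Two related compounds give numbers there: compound 1 `O=C(NCc1ccc(CNS(=O)(=O)c2ccccc2F)cc1)c1cc2ccccn2n1` reaches 40% and compound 3 `O=C(NCc1ccc(CNS(=O)(=O)c2ccc3c(c2)CCO3)cc1)c1cccnc1` reaches 60%. Compound 4 `O=C(NCc1ccc(CNS(=O)(=O)c2ccc3c(c2)CCO3)cc1)c1cc2ccccn2n1` is not yet measured. It differs from compound 2 in one place: a group of 9 heavy atoms (7 carbon, 2 nitrogen; one five-membered aromatic ring with 2 hetero atoms, one six-membered aromatic ring with 1 hetero atom) in place of a group of 7 heavy atoms (5 carbon, 2 nitrogen; one five-membered aromatic ring with 2 hetero atoms), on a carbonyl carbon. Among the measured compounds shown here, with no measured step of this kind, the size of the change in this assay can only be guessed, and no direction beyond the scatter is expected. Compound 4 is estimated to give 50% in this assay, most likely between 25% and 75%, guided by compound 1 with 40% and compound 3 with 60%.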

Compound 4, a percentage reported as inhibition, at one concentration (the size of the read-out at that concentration, not a potency): 40%
Compound 4: middle estimate off by 10 percentage points, on the high side, within the range that was stated.
By their numbers in this assay, from the lowest: compounds 1 and 4 (each within the scatter of the next); then compound 3.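

On the carbonyl carbon, the larger two-ring group in place of the single six-membered ring gives a number 20 percentage points lower from compound 3 to compound 4 (beyond the scatter) in this assay and so shows that this position responds to the group it carries. On the sulfonyl sulfur, with that two-ring group kept on the carbonyl carbon, the change gives no change at the digits printed from compound 1 to compound 4 (within the scatter) and the two sulfonyl groups read alike here. Nothing given explains either step.

Compound 2 has no number, so any comparison of it with compound 4 stays unread. Going by these compounds, how an amine or a carboxylic acid on the carbonyl carbon would read remains open.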